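Tert-butyl to trifluoromethyl on a shared ester side chain

The source may report more compounds than this note shows. Statements on the series, on what has been measured and on what is new or still open speak of the compounds shown alone.

In an ADME assay on HepG2 cells (Homo sapiens) for cytotoxicity, read by MTT assay, with a stated time of 24 h (on this read-out lower numbers stand for higher toxicity in this test and higher numbers for lower toxicity in this test), compound 1 `CCc1ccccc1C(=O)OCc1cn(-c2ccnc3cc(Cl)ccc23)nn1` gives > 2550000 nM, a limit of the test rather than a number.
Compound 2 `CC(C)(C)c1ccc(C(=O)OCc2cn(-c3ccnc4cc(Cl)ccc34)nn2)cc1` gives > 2380000 nM in this assay, again a limit.
Compound 3 `COc1c(F)c(F)cc(C(=O)OCc2cn(-c3ccnc4cc(Cl)ccc34)nn2)c1F` gives > 2230000 nM in this assay, also a limit.

Compound 2 therefore stands where every measured compound stands: at a limit of this assay, with no number to place it above or below compound 1 or compound 3. Among the measured compounds shown here, the one step between measured neighbours, a step that the two limits leave unreadable from compound 1 to compound 2, cannot be read for the same reason. The evidence available is the limit of > 2380000 nM in this assay, at which 1 of the 3 values shown sits, together with the limit of > 2550000 nM in this assay, at which 1 of the 3 values shown sits, and (the limit of > 2230000 nM in this assay, at which 1 of the 3 values shown sits), and none of these gives a size for any change.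

Compound 4 `O=C(OCc1cn(-c2ccnc3cc(Cl)ccc23)nn1)c1ccc(C(F)(F)F)cc1` differs from compound 2 in one place: trifluoromethyl in place of tert-butyl on an aromatic carbon. For the measured compounds named here, no measured step bears on this change, since every step among the measured compounds is hidden by the limits. What the three measurements share is that no exchange of the group on the ester-bearing ring has yet brought a compound within the range that this assay reports as a number.

For compound 4 the expectation is therefore a limit again, and the estimate in this assay is 2400000 nM, within 600000 nM to 3000000 nM. The expected step from compound 2 is a step that the limit leaves unreadable from compound 2 to compound 4, no change beyond the scatter.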

Compound 4, half-maximal cytotoxic concentration: 1070000 nM
The estimate for compound 4 lay 2.2-fold (0.35 log units) above the measured number, within the range that was stated.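

In this assay, among the compounds shown here, compound 4 gives 1070000 nM, the first real number in this set rather than a limit, so the group on this ring can bring the read-out into the range the test reports. Trifluoromethyl in place of tert-butyl, on an aromatic carbon and with no change in the number of heavy atoms, gives an at least 2.2-fold lower number from compound 2 to compound 4 (0.34 log units; beyond the scatter), which means higher toxicity in this test, and the wider exchange of 2-ethylphenyl for 4-(trifluoromethyl)phenyl gives an at least 2.3-fold lower number from compound 1 to compound 4 (0.37 log units; beyond the scatter). Nothing measured here explains why this exchange lowers the number.

Going by these compounds, the step from compound 1 to compound 2 still cannot be read, and with limits on both sides of these comparisons, the full size of the two new steps also stays unknown. The compounds shown leave open how an amine, a carboxylic acid or a longer chain at this same place on the ring would compare with trifluoromethyl, and whether any such group would give a number lower than that of compound 4.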